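Notes on a ring swap at the amide-type nitrogen

The compounds below may be only part of what the source reports. "The series", "measured", "known", "first", "only" and "open" are said of these compounds alone.

compound 1 `CC(C)(C)c1conc1N1C(=O)CSC1c1cccc(C(=O)NCCCCc2ccccc2)c1` — > 1000 nM
compound 2 `COc1ccccc1N1C(=O)CSC1c1cccc(C(=O)NCCCCN2C(=O)C=CC2=O)c1` — > 1000 nM

In a functional assay on HOS-TE85 cells (Homo sapiens) for inhibition, read by CCK-8 assay, with a stated time of 72 h (a higher number here means a weaker inhibitor, a lower number a stronger inhibitor), compound 1 gives > 1000 nM, which is a limit of the assay and not a number. Compound 2 likewise shows only a limit in this assay, > 1000 nM. Compound 1 therefore stands at the limit of > 1000 nM in this assay, at which 2 of the 2 values shown sit, and nothing finer about its place follows from the numbers shown. Among the compounds with values here, the two measured compounds differ in more than one place, so no step between them is available and only their two limit values can be stated.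

Compound 3 `COc1ccc(N2C(=O)CSC2c2cccc(C(=O)NCCCCc3ccccc3)c2)c(OC)c1` is not yet measured. It differs from compound 1 in one place: a group of 10 heavy atoms (8 carbon, 2 oxygen; one six-membered aromatic ring of carbon only) in place of a group of 9 heavy atoms (7 carbon, 1 nitrogen, 1 oxygen; one five-membered aromatic ring with 2 hetero atoms), on an amide-type nitrogen in a ring. Within the data shown here, no measured step covers this change, so the expectation for this assay rests on compound 1 alone, and nothing suggests a move of any particular direction. The step is expected to be none beyond the scatter, a step that the limit leaves unreadable from compound 1 to compound 3. Compound 3 is expected at 1500 nM, with a range from 600 nM to 6000 nM, and a limit reading again the most likely outcome.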

Compound 3, half-maximal inhibitory concentration: 90.4 nM
Compound 3: the middle estimate sits 17-fold (1.22 log units) above what was measured; measured number below the stated range.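

In this assay, within the data shown here, the group on the amide-type nitrogen in the ring proves not to be indifferent: 2,4-dimethoxyphenyl entering for the five-membered aromatic ring with 2 hetero atoms gives an at least 11-fold lower number from compound 1 to compound 3 (1.04 log units; beyond the scatter), the first step that can be read. Compound 1 gives > 1000 nM, which is a limit of the assay and not a number. The step is therefore a minimum and not an exact size, and compound 3 is the only compound shown with a value off that limit: the limit of > 1000 nM in this assay, at which 2 of the 3 values shown sit.

From the compounds shown here alone, whether the change in number belongs to the two methoxy groups or to the six-membered aromatic ring of carbon alone stays open; a plain phenyl or a single methoxy on the phenyl at this nitrogen would separate the two. Also open, going by these compounds, is how much the phenyl at the end of the amide chain matters with 2,4-dimethoxyphenyl in place, which an amine or a carboxylic acid at that chain end would test in this assay.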